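The compounds below may be only part of what the source reports. "The series", "measured", "known", "first", "only" and "open" are said of these compounds alone.

Compound 1, `Cc1nc(S(C)(=O)=O)ccc1Oc1ncnc(OC2CCN(C(=O)OC(C)(C)CF)CC2)c1F`, in a functional assay on isolated protein for inhibition of Glucose-dependent insulinotropic receptor (Rattus norvegicus), read by HTRF and cAMP accumulation; on this read-out lower numbers stand for an effect already at smaller amounts and higher numbers for an effect only at larger amounts of compound: 138 nM
Compound 2, `Cc1nc(S(C)(=O)=O)ccc1Oc1ncnc(OC2CCN(C(=O)OC(C)F)CC2)c1F`, in this assay: 315 nM
Compound 3, `Cc1nc(S(C)(=O)=O)ccc1Oc1ncnc(OC2CCN(C(=O)O[C@@H](C)C(F)(F)F)CC2)c1F`, in this assay: 109 nM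

Compound 3 has the lowest of the three numbers, yet one of its two gaps is only a 1.3-fold lower number from compound 1 to compound 3 (0.10 log units; within the scatter), while the other is a 2.9-fold lower number from compound 2 to compound 3 (0.46 log units; beyond the scatter). Compound 4, `Cc1nc(S(C)(=O)=O)ccc1Oc1ncnc(OC2CCN(C(=O)SC3CC3)CC2)c1F`, differs from compound 3 by a group of 4 heavy atoms (3 carbon, 1 sulfur; one three-membered non-aromatic ring of carbon only) in place of a group of 7 heavy atoms (3 carbon, 1 oxygen, 3 fluorine; no ring), on a carbonyl carbon. Within the data shown here, none of the measured steps touches this kind of change; all of them exchange one fluorinated alkoxy group for another at the same carbonyl, and those steps were modest, a 2.3-fold higher number from compound 1 to compound 2 (0.36 log units; beyond the scatter) and a 2.9-fold lower number from compound 2 to compound 3 (0.46 log units; beyond the scatter). Among the measured compounds shown here, no step therefore bears directly on compound 4, and its direction in this assay is open. For compound 4 a step of about a 1.8-fold higher number from compound 3 to compound 4 (0.26 log units; within the scatter) is estimated, giving an expected 200 nM in this assay, in the range 60 nM to 700 nM.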

Compound 4, half-maximal effective concentration: 126 nM
Compound 4: the middle estimate sits 1.6-fold (0.20 log units) above what was measured, and the stated range covers the measured number.
By their numbers in this assay, from the lowest: compounds 3, 4 and 1 (each within the scatter of the next); then compound 2.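

In this assay, a three-membered carbon ring joined through sulfur can replace 1-(trifluoromethyl)ethoxy on the carbonyl carbon with little change (a 1.2-fold higher number from compound 3 to compound 4 (0.06 log units; within the scatter)), so among these compounds neither fluorine, an oxygen link nor a defined stereocentre is needed for a number in this range. The new group also reads level with the fluorinated group of compound 1 (a 1.1-fold lower number from compound 1 to compound 4 (0.04 log units; within the scatter)) and clear of that of compound 2 (a 2.5-fold lower number from compound 2 to compound 4 (0.40 log units; beyond the scatter)). Nothing measured here gives a reason for this.

The compounds shown leave open how a cyclopropyl group joined through oxygen, an isopropyl group joined through sulfur or an amine on this carbonyl carbon would read. Whether the sulfur or the ring matters more therefore remains unsettled.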